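Chloro in Place of Methyl on the Pendant Aryl Ring

The source may hold more compounds than are shown below. What is called first, only, known or untested is meant among the compounds shown, and "the series" means these compounds.

Compound 1, `Cc1cccc([C@@H]2CN(C(C)C)C[C@H]2C(=O)N2CCN(c3c(F)cccc3[C@@H](NC(=O)CCN(C)C)C(C)C)CC2)c1`, is the weaker of the two measured compounds in an assay on HEK293 cells for displacement of a labelled ligand from Melanocortin receptor 4 (Homo sapiens); on this read-out higher numbers stand for weaker inhibition and lower numbers for stronger inhibition: compound 1 gives 470 nM, the highest of the two numbers at hand. Within the data shown here, the other measured compound, compound 2, `Cc1ccc(N2CCN(C(=O)[C@@H]3CN(C4CCOCC4)C[C@H]3c3ccc(Cl)cc3)CC2)c([C@@H](NC(=O)[C@H](C)N)C(C)C)c1`, gives 1 nM in this assay; it differs from compound 1 in several places at once, so the two values show only that compound 2 sits far lower, well beyond the scatter. The unmeasured compound 3, `CC(C)[C@H](NC(=O)CCN(C)C)c1cccc(F)c1N1CCN(C(=O)[C@@H]2CN(C(C)C)C[C@H]2c2cccc(Cl)c2)CC1`, arises from compound 1 by a single change: chloro in place of methyl on an aromatic carbon. Among the measured compounds shown here, no measured pair isolates this change, so its size cannot be read from the data. The step of a 1.3-fold lower number from compound 1 to compound 3 (0.13 log units; within the scatter) is expected to be small, at most a modest move toward a lower number and possibly none beyond the scatter. Compound 3 is therefore estimated to give about 350 nM in this assay, with a likely range from 120 nM to 1000 nM.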

Compound 3, inhibition constant: 370 nM
Beside the measured number, compound 3's estimate is 1.1-fold (0.02 log units) below it, and the stated range covers the measured number.
By their numbers in this assay, from the lowest: compound 2; then compounds 3 and 1 (each within the scatter of the next).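

Among these compounds, until now no pair isolated this change, and here it can be read directly: going from 3-methylphenyl to 3-chlorophenyl gives a 1.3-fold lower number from compound 1 to compound 3 (0.10 log units; within the scatter) in this assay. On the core of compound 1, then, chloro can stand in for methyl on this aromatic carbon, meta to a large group, with no difference that stands out from the scatter. Nothing at hand bears on why the two groups read alike at this place.

Still open, from the compounds shown here alone, is how an amine, a carboxylic acid or a longer alkyl chain would read at this same place. Also open, going by these compounds, is whether chloro in place of methyl would read the same way on a compound carrying the other groups of compound 2, which differs from compound 1 in several places at once.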